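A few compounds are considered here, and "the series" means these few. Any claim that something is new, unique, unknown or untested is made for them only; others in the source may bear on it.

Measured compounds:
Compound 1 `CC(C)Oc1ccccc1CNC(=O)c1ccc2cncc(Br)c2n1`: 9 ug/mL
Compound 2 `C=Cc1cncc2ccc(C(=O)NCc3ccccc3OC(C)C)nc12`: 17 ug/mL
Compound 3 `CC(C)Oc1ccccc1CNC(=O)c1ccc2cnccc2n1`: 2.5 ug/mL

In a functional assay on Hs68 cells (Homo sapiens) for cytotoxicity (on this read-out higher numbers stand for lower toxicity in this test and lower numbers for higher toxicity in this test), compound 3 stands lowest of the three numbers. Its nearest neighbour is compound 1, with a 3.6-fold lower number from compound 1 to compound 3 (0.56 log units; beyond the scatter); the furthest is compound 2, with a 6.8-fold lower number from compound 2 to compound 3 (0.83 log units; beyond the scatter). The remaining pair gave a 1.9-fold higher number from compound 1 to compound 2 (0.28 log units; within the scatter).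

Compound 4 `CC[C@H](C)Oc1ccccc1CNC(=O)c1ccc2cnccc2n1` differs from compound 3 by methyl in place of hydrogen on a saturated chain carbon, two bonds along the chain from an oxygen on an aromatic ring, which at one bond further out reads isopropoxy to sec-butoxy. None of the three measured steps touches this part of the molecule: each of them swaps the group on an aromatic carbon of the shared core while the isopropoxy group stays fixed. Within the data shown here, the data therefore hold no step that bears directly on the change from compound 3 to compound 4, and the account can only expect a number close to that of compound 3, with no step beyond the scatter in either direction. Compound 4 is thus estimated at 2.5 ug/mL, with a range from 1.2 ug/mL to 6 ug/mL. This estimate means an expected step of no change at the digits printed from compound 3 to compound 4 (within the scatter).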

Compound 4, half-maximal cytotoxic concentration: 3.1 ug/mL
Estimate against measurement, compound 4: 1.2-fold (0.09 log units) below; low and high end bracket the measured number.
By their numbers in this assay, from the lowest: compounds 3 and 4 (each within the scatter of the next); then compounds 1 and 2 (each within the scatter of the next).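

In this assay, adding a methyl that turns the isopropoxy group of compound 3 into the sec-butoxy group of compound 4 gives a step within the scatter (a 1.2-fold higher number from compound 3 to compound 4 (0.09 log units; within the scatter)), so this change on a saturated chain carbon, two bonds along the chain from an oxygen on an aromatic ring, does not separate the two compounds. Among these compounds, the earlier steps all fell on an aromatic carbon of the shared core, and two of them went beyond the scatter, so this is the first reading at the alkoxy side of the molecule. Nothing at hand offers an explanation for this result.

From the compounds shown here alone, whether a longer chain, a cyclopentyloxy group or a chain bearing an amine at this place would stay within the scatter of compound 3 remains open. So does whether the sec-butoxy group would give the same picture on the bromo core of compound 1 or the vinyl core of compound 2.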